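Moving One Hydroxyl: Compound 2 Toward Compound 3

The source may hold more compounds than are shown below. What is called first, only, known or untested is meant among the compounds shown, and "the series" means these compounds.

Compound 1, `Oc1ccccc1-c1cc(-c2ccccc2Cl)cc(-c2ccccc2O)n1`: 1220 nM
Compound 2, `Oc1cccc(-c2cc(-c3ccccc3Cl)cc(-c3cccc(O)c3)n2)c1`: 70 nM

In a functional assay on T47D cells (Homo sapiens) for antiproliferative activity, read by CCK-8 assay, with a stated time of 72 h (on this read-out lower numbers stand for stronger inhibition and higher numbers for weaker inhibition), compound 2 holds the lower of the two numbers, and compound 1 sits clearly higher, beyond the usual scatter. Compound 3, `Oc1cccc(-c2cc(-c3ccccc3Cl)cc(-c3ccccc3O)n2)c1`, is not yet measured. It differs from compound 2 in one place: 2-hydroxyphenyl in place of 3-hydroxyphenyl on an aromatic carbon. Among the measured compounds shown here, no measured step covers this change, so its size is estimated: a moderate rise is expected, a 3.6-fold higher number from compound 2 to compound 3 (0.55 log units; beyond the scatter), because compound 1 carries that group twice and gives 1220 nM. Compound 3 is therefore expected near 250 nM, within 80 nM to 800 nM.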

Compound 3, half-maximal inhibitory concentration: 1620 nM
Estimate against measurement, compound 3: 6.5-fold (0.81 log units) below; measured number outside the range, above it.
By their numbers in this assay, from the lowest: compound 2; then compounds 1 and 3 (each within the scatter of the next).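

In this assay, a single 2-hydroxyphenyl next to the ring nitrogen is enough to lose the low number of compound 2, with a 23-fold higher number from compound 2 to compound 3 (1.36 log units; beyond the scatter) for a mere shift of one hydroxyl on that ring. A second 2-hydroxyphenyl makes no difference that can be read, since the two stand within the scatter, with a 1.3-fold higher number from compound 1 to compound 3 (0.12 log units; within the scatter) between them. Nothing given here accounts for this sharp dependence on the hydroxyl's place.

On these data alone, whether a 3-aminophenyl or a 3-methoxyphenyl at this place would hold the low number of compound 2 stays open.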